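The source may hold more compounds than are shown below. What is called first, only, known or untested is meant among the compounds shown, and "the series" means these compounds.

Measured in a functional assay on MCF7 cells (Homo sapiens) for antiproliferative activity, read by MTT assay, with a stated time of 72 h; a lower number here means a stronger inhibitor, a higher number a weaker inhibitor:
Compound 1 (`CCN1CCN(c2cc(C)c3cc(NC(=O)c4ccc(F)c(F)c4)ccc3n2)CC1`): 5230 nM
Compound 2 (`CCN1CCN(c2cc(C)c3cc(NC(=O)c4cc5ccccc5[nH]4)ccc3n2)CC1`): 2950 nM

Compound 2 stands level with compound 1 on these numbers: the two values lie within the scatter of each other, so they set no order in the series. Compound 3 (`CCN1CCN(c2cc(C)c3cc(NC(=O)c4ccccc4Cl)ccc3n2)CC1`) is the next to be read, and its difference from compound 2 is 2-chlorophenyl in place of 1H-indol-2-yl on a carbonyl carbon. In words, this is 2-chlorophenyl in place of 1H-indol-2-yl on a carbonyl carbon.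

Among the compounds with values here, one measured step bears on this change, since it concerns the same carbonyl carbon: a 1.8-fold lower number from compound 1 to compound 2 (0.25 log units; within the scatter). That step stays within the scatter. Compound 1, with 3,4-difluorophenyl at this place, gives 5230 nM, so one exchange of 1H-indol-2-yl for a phenyl-bearing group is already on record, and it moved the number by no more than the scatter. Within the data shown here, no measurement yet covers 2-chlorophenyl itself. The expected result is therefore no step beyond the scatter in this assay, with no firm direction. The estimated step is a 1.3-fold higher number from compound 2 to compound 3 (0.11 log units; within the scatter). For compound 3 the estimate is 3800 nM, with an expected range of 1800 nM to 8000 nM.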

Compound 3, half-maximal inhibitory concentration: > 50000 nM
Compound 3 gave a limit, no number; the forecaster's own chance of this, stated with the estimate: 10%; at least 13-fold (1.11 log units) between middle value and limit.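

In this assay compound 3 gives > 50000 nM, and this reading is a limit of the assay, not a number: the limit of > 50000 nM in this assay, at which 1 of the 3 values shown sits. The earlier compounds shown here left the group on the carbonyl carbon looking exchangeable, with a 1.8-fold lower number from compound 1 to compound 2 (0.25 log units; within the scatter), but 2-chlorophenyl breaks that picture, giving an at least 16-fold higher number from compound 2 to compound 3 (1.22 log units; beyond the scatter) and also an at least 9.5-fold higher number from compound 1 to compound 3 (0.98 log units; beyond the scatter). This place in the series therefore does respond to the group it carries, and a six-membered aromatic ring on the carbonyl carbon does not settle the reading by itself, as compound 1 and compound 3 both carry one and still stand apart by a step beyond the scatter.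

Going by these compounds, the true size of both new steps stays unknown, as only a limit is available for compound 3, and these compounds do not separate the chlorine from the rest of the 2-chlorophenyl group. A plain phenyl or a pyridyl group on the same carbonyl carbon would show whether the loss follows the chlorine or extends to other simple aromatic rings at this place.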